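The compounds below may be only part of what the source reports. "The series", "measured", "known", "first", "only" and "open" are said of these compounds alone.

Working notes on the series. The read-out throughout is a functional assay on MCF7 cells (Homo sapiens) for cytotoxicity, read by MTT assay, with a stated time of 72 h; on this read-out lower numbers stand for stronger inhibition and higher numbers for weaker inhibition. Compound 1, `O=C(Nc1ccc(Oc2ccnc3[nH]ccc23)c(F)c1)c1nn(-c2ccc(Cl)c(F)c2)ccc1=O`, gives 11600 nM in this assay. Compound 2, `Cn1ccc2c(Oc3ccc(NC(=O)c4nn(-c5ccc(Cl)cc5)ccc4=O)cc3F)ccnc21`, carries a methyl on the core and a 4-chlorophenyl on the ring nitrogen; for compound 2 this assay reports only a limit, > 60000 nM, not a number. Compound 3, `Cn1ccc2c(Oc3ccc(NC(=O)c4nn(-c5ccc(Br)cc5)ccc4=O)cc3F)ccnc21`, has 4-bromophenyl in that position and gives 33600 nM. Of the two numbers in hand compound 3 stands highest; its nearest neighbour is compound 1, whose lower number lies beyond the scatter. The third value shown is the limit of > 60000 nM in this assay, at which 1 of the 3 values shown sits.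

Among the measured compounds shown here, the only measured step touching the ring-nitrogen aryl is an at least 1.7-fold lower number from compound 2 to compound 3 (0.25 log units; that floor lies within the scatter), a change whose floor lies within the scatter.

Compound 4, `Cn1ccc2c(Oc3ccc(NC(=O)c4nn(-c5ccc(Cl)c(F)c5)ccc4=O)cc3F)ccnc21`, departs from compound 3 by 4-chloro-3-fluorophenyl in place of 4-bromophenyl on an aromatic nitrogen. Compound 1 bears the same 4-chloro-3-fluorophenyl on the unmethylated core and sits lower than compound 3, while compound 2, which shares the methylated core and the chloro, gave only a limit. On this basis the move from compound 3 to compound 4 is expected to be a 1.0-fold higher number from compound 3 to compound 4 (0.02 log units; within the scatter), not beyond the scatter, with a limit reading possible. Compound 4 is estimated at 35000 nM, between 15000 nM and 80000 nM.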

Compound 4, half-maximal inhibitory concentration: 16600 nM
Estimate against measurement, compound 4: 2.1-fold (0.32 log units) above, and the stated range covers the measured number.
By their numbers in this assay, from the lowest: compounds 1 and 4 (each within the scatter of the next); then compound 3. At a limit, above all of these: compound 2.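

In this assay, 4-chloro-3-fluorophenyl in place of 4-bromophenyl on the ring nitrogen gives a 2.0-fold lower number from compound 3 to compound 4 (0.31 log units; beyond the scatter), so this aryl position now has a measured step beyond the scatter, which the earlier comparison of the chloro and bromo compounds did not provide. Fluoro in place of hydrogen on the aryl ring gives an at least 3.6-fold lower number from compound 2 to compound 4 (0.55 log units; beyond the scatter), while methyl in place of hydrogen on an aromatic nitrogen of the core gives a 1.4-fold higher number from compound 1 to compound 4 (0.16 log units; within the scatter), which lies within the scatter and so shows that, with this aryl group, the methylated and unmethylated cores cannot be told apart in this assay. The fluoro step has only a floor, since compound 2 gives a limit and not a number: the limit of > 60000 nM in this assay, at which 1 of the 4 values shown sits.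

The compounds shown leave open whether fluoro on the ring would also lower the number with bromo as the para group, as the step from compound 3 to compound 4 changes both halogens at once. They also leave open how this position responds to a group of another kind on the aryl ring, such as an amine or a carboxylic acid.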